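Benzylamino to Benzyloxy on a Carbonyl Carbon

The compounds below may be only part of what the source reports. "The series", "measured", "known", "first", "only" and "open" are said of these compounds alone.

Of the compounds shown here, three built on one shared core have been measured in a functional assay on cells (Oocyte) for inhibition of Voltage-dependent T-type calcium channel subunit alpha-1H (Homo sapiens), tested at 100 uM; a higher number here means more inhibition at the concentration tested (going by the name of the read-out), a lower number less inhibition. Compound 1 `COC(=O)CC1c2ccccc2N=C(c2ccccc2)N1c1ccccc1` gives 51.5%. Compound 2 `O=C(O)CC1c2ccccc2N=C(c2ccccc2)N1c1ccccc1` gives 7.2%, and compound 3 `O=C(CC1c2ccccc2N=C(c2ccccc2)N1c1ccccc1)NCc1ccccc1` gives 14.8%. Compound 3 thus stands second highest of the three numbers: its nearest neighbour is compound 2, within the scatter, and its furthest is compound 1, beyond it. The step of a number 36.7 percentage points lower from compound 1 to compound 3 (beyond the scatter) is large, as is a number 44.3 percentage points lower from compound 1 to compound 2 (beyond the scatter), whereas a number 7.6 percentage points higher from compound 2 to compound 3 (within the scatter) stays within the scatter.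

Compound 4 `O=C(CC1c2ccccc2N=C(c2ccccc2)N1c1ccccc1)OCc1ccccc1` has not yet been measured. It differs from compound 3 as follows: benzyloxy in place of benzylamino on a carbonyl carbon. This change bears on the earlier step because a number 36.7 percentage points lower from compound 1 to compound 3 (beyond the scatter) arose when benzylamino replaced methoxy on the same carbonyl carbon, and compound 4 returns an oxygen to that carbonyl carbon. Compound 4 is therefore expected to rise, with a number 23.2 percentage points higher from compound 3 to compound 4 (beyond the scatter). A full return to the level of compound 1 is not assumed, since compound 1 carries methoxy rather than benzyloxy. Compound 4 is estimated at 38%, within 15% to 60%.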

Compound 4, a percentage reported as inhibition, at one concentration (the size of the read-out at that concentration, not a potency): 14.2%
The estimate for compound 4 lay 23.8 percentage points above the measured number; measured number outside the range, below it.
By their numbers in this assay, from the lowest: compounds 2, 4 and 3 (each within the scatter of the next); then compound 1.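

Replacing benzylamino with benzyloxy on the carbonyl carbon makes no difference that can be told apart in this assay (a number 0.6 percentage points lower from compound 3 to compound 4 (within the scatter)), so an oxygen at this place does not by itself restore the higher number of compound 1. Compound 4 also stays within the scatter of the carboxylic acid (a number 7 percentage points higher from compound 2 to compound 4 (within the scatter)), yet it falls well short of the methyl ester (a number 37.3 percentage points lower from compound 1 to compound 4 (beyond the scatter)), which shows that the ester link alone is not enough and that benzyl on that oxygen gives a far lower number than methyl. No measurement offered here explains this result.

On these data alone, what remains open is how the number changes between methyl and benzyl, as an ethyl or a longer chain on the same oxygen would show. As far as these compounds go, whether methylamino on the carbonyl carbon would match methoxy also remains open.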